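This account rests on a few compounds, and the source may have more. Where it says the series, first, only, none or still open, it means among the compounds named here.

Measured compounds in a functional assay (spleen, spleen) for activation, with Mus musculus as the target; on this read-out lower numbers stand for an effect already at smaller amounts and higher numbers for an effect only at larger amounts of compound:
compound 1 `COc1ccc(Cn2c(O)nc3c(N)ncnc32)cc1`: 10 uM
compound 2 `CCSc1nc(N)c2nc(O)n(Cc3ccccc3)c2n1`: 0.1 uM
compound 3 `Cc1ccc(Cn2c(O)nc3c(N)ncnc32)cc1`: 10 uM

In this assay compound 2 stands lowest of the three numbers; compound 1 and compound 3 both lie a long way above it, well beyond the scatter. Among the measured compounds shown here, the only measured step, no change at the digits printed from compound 1 to compound 3 (within the scatter), concerns a substituent on the benzyl ring of a different core and does not touch the sulfur chain. Compound 4 `CCCSc1nc(N)c2nc(O)n(Cc3ccccc3)c2n1` differs from compound 2 by methyl in place of hydrogen on a saturated chain carbon, two bonds along the chain from a sulfur. For the measured compounds named here, no measured step bears on a change of this kind, so the expectation rests on compound 2 alone and on the small size of the change. Compound 4 is therefore estimated at 0.1 uM (range 0.03 uM to 0.3 uM), an expected step of no change at the digits printed from compound 2 to compound 4 (within the scatter).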

Compound 4, minimum effective concentration: 0.01 uM
Estimate against measurement, compound 4: 10-fold (1.00 log units) above; the measured number lies below the stated range.
By their numbers in this assay, from the lowest: compound 4; then compound 2; then compounds 1 and 3 (each within the scatter of the next).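

In this assay, the change from ethylsulfanyl to propylsulfanyl gives a 10-fold lower number from compound 2 to compound 4 (1.00 log units; beyond the scatter), beyond the scatter. This shows that the sulfur chain is not indifferent to its length: one methyl on a saturated chain carbon, two bonds along the chain from a sulfur, already moves the number, which the earlier aromatic change could not show. Nothing given here accounts for this step. On these data alone, whether the number keeps falling with a longer chain such as butylsulfanyl remains open. So does the effect of a branched isopropylsulfanyl group or an amine at the chain end.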